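Methyl to methoxy on the outer ring of compound 2

This account rests on a few compounds, and the source may have more. Where it says the series, first, only, none or still open, it means among the compounds named here.

The measured compounds and their values in a physicochemical assay for lipophilicity, in phosphate buffer, measured as octanol-water partition; on this read-out lower numbers stand for lower lipophilicity and higher numbers for higher lipophilicity:
- compound 1, `O=C(NC(=S)Nc1ccccc1)Nc1ccc2c(c1)C(=O)C(=O)N2Cc1ccccc1`: 2.48
- compound 2, `Cc1cccc(NC(=S)NC(=O)Nc2ccc3c(c2)C(=O)C(=O)N3Cc2ccccc2)c1`: 2.92
- compound 3, `COc1cccc(NC(=S)NC(=O)Nc2ccc3c(c2)C(=O)C(=O)N3Cc2ccccc2)c1`: 2.4

Compound 2 stands highest of the three in this assay. The step of a number 0.44 log units higher from compound 1 to compound 2 (beyond the scatter) is beyond the scatter, and so is the step of a number 0.52 log units lower from compound 2 to compound 3 (beyond the scatter). Compound 1 and compound 3 differ by a number 0.08 log units lower from compound 1 to compound 3 (within the scatter), which lies within the scatter.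

Compound 4, `COc1ccc(NC(=S)NC(=O)Nc2ccc3c(c2)C(=O)C(=O)N3Cc2ccccc2)cc1`, is not yet measured. It differs from compound 2 in one place: 4-methoxyphenyl in place of 3-methylphenyl on an amide-type nitrogen. The step that bears most directly on this change is a number 0.52 log units lower from compound 2 to compound 3 (beyond the scatter), where a methoxy took the place of a methyl on the same outer ring, though at a different position. The step of a number 0.08 log units lower from compound 1 to compound 3 (within the scatter) adds that a methoxy on that ring left the number essentially where the unsubstituted compound 1 stood. Only one position of the methoxy has been measured, so the new position carries some uncertainty.

A step downward from compound 2 is therefore expected, of about the size seen for compound 3, giving a number 0.47 log units lower from compound 2 to compound 4 (beyond the scatter). Compound 4 is estimated at 2.45, with a range from 2.1 to 2.8.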

Compound 4, partition coefficient: 2.39
For compound 4 the middle estimate is 0.06 log units above the measured one; the measured number falls inside the stated range.
By their numbers in this assay, from the lowest: compounds 4, 3 and 1 (each within the scatter of the next); then compound 2.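

In this assay, moving the methoxy from the 3-methoxyphenyl of compound 3 to the 4-methoxyphenyl of compound 4 gives a number 0.01 log units lower from compound 3 to compound 4 (within the scatter), so this read-out does not tell these two methoxy-bearing rings apart. For the compounds shown here, the new ring also stays level with the plain phenyl ring, with a number 0.09 log units lower from compound 1 to compound 4 (within the scatter), whereas replacing the 3-methylphenyl group gives a number 0.53 log units lower from compound 2 to compound 4 (beyond the scatter), which leaves compound 2 as the only one of the four compounds that stands apart from the rest. No measurement shown here accounts for the separation of compound 2 from the others.

The compounds shown leave open whether a 4-methylphenyl group would stay with compound 2 or fall level with compound 1, a comparison that would show whether the result for compound 2 belongs to the methyl group alone or to the methyl group at that particular position. They also leave open how an amine, a carboxylic acid or a longer chain such as ethoxy on this outer ring would compare with the methyl and methoxy groups.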